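Changing the aryl group on the amide nitrogen

The source may hold more compounds than are shown below. What is called first, only, known or untested is meant among the compounds shown, and "the series" means these compounds.

Among the measured compounds shown here, in a functional assay on MGC-803 cells (Homo sapiens) for inhibition, read by CCK-8 assay, with a stated time of 48 h (a higher number here means a weaker inhibitor, a lower number a stronger inhibitor), compound 2 (`COc1ccc(CN(C(=O)CSC(=S)N2CCN(C(=O)OC(C)(C)C)CC2)c2cc(OC)c(OC)c(OC)c2)cc1`) gives 310 nM and holds the lower of the two numbers so far, while compound 1 (`COc1ccc(CN(C(=O)CSC(=S)N2CCN(C)CC2)c2cc(OC)c(OC)c(OC)c2)cc1`) gives 1280 nM in the same test. Compound 3 (`COc1ccc(CN(C(=O)CSC(=S)N2CCN(C(=O)OC(C)(C)C)CC2)c2ccc(C)cc2)cc1`) keeps the tert-butoxycarbonyl group of compound 2 and differs elsewhere (4-methylphenyl in place of 3,4,5-trimethoxyphenyl on an amide-type nitrogen), with 4-methylphenyl in place of 3,4,5-trimethoxyphenyl on an amide-type nitrogen. For the measured compounds named here, only one measured step exists (a 4.1-fold lower number from compound 1 to compound 2 (0.62 log units; beyond the scatter)). It lies beyond the scatter, but it concerns tert-butoxycarbonyl in place of methyl on an amine nitrogen in a ring, so it bears on the new change only as a rough guide to size. Going by the values given here, no measured compound varies the group on the amide-type nitrogen, so the direction is a judgement. A higher number is expected in this assay, of roughly the size of that one measured step, and a result within the scatter remains possible. The expected step is a 3.9-fold higher number from compound 2 to compound 3 (0.59 log units; beyond the scatter) on this reading. In this assay the estimate for compound 3 is 1200 nM with a range of 350 nM to 5000 nM expected.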

Compound 3, half-maximal inhibitory concentration: > 20000 nM
Compound 3 gave a limit, no number; the forecaster's own chance of this, stated with the estimate: 5%; at least 16-fold (1.22 log units) between middle value and limit.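

Position notes: the group on the amide-type nitrogen now carries the largest effect in the series, with 4-methylphenyl in place of 3,4,5-trimethoxyphenyl giving an at least 64-fold higher number from compound 2 to compound 3 (1.80 log units; beyond the scatter), while the only other step, at the amine nitrogen in a ring, gives a 4.1-fold lower number from compound 1 to compound 2 (0.62 log units; beyond the scatter). In this assay, compound 3 gives > 20000 nM, which is a limit of the assay and not a number. Among the compounds shown here, the true size of the step therefore stays unknown, and this is the only value of its kind so far: the limit of > 20000 nM in this assay, at which 1 of the 3 values shown sits.

The change replaces a group of 12 heavy atoms, 3 of them oxygen, with one of 7 carbon atoms, and this single pair cannot separate the loss of the methoxy groups from the gain of the methyl group. Open points are how an unsubstituted phenyl or a phenyl carrying a single methoxy group on the amide-type nitrogen would read, and whether the same swap has a comparable effect with methyl rather than tert-butoxycarbonyl on the ring amine.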